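The source may report more compounds than this note shows. Statements on the series, on what has been measured and on what is new or still open speak of the compounds shown alone.

Compound 3 `COc1ccc(NC(=S)N/N=C/c2cccs2)cc1` reaches only a limit in a functional assay on U-251 cells (Homo sapiens) for inhibition, read by sulforhodamine B assay, with a stated time of 48 h (on this read-out lower numbers stand for stronger inhibition of growth and higher numbers for weaker inhibition of growth), at > 100000 nM, and this is not a number. the limit of > 100000 nM in this assay, at which 1 of the 3 values shown sits, is the only such case so far. In this assay compound 1 `S=C(N/N=C/c1cccs1)Nc1ccc(Cl)cc1` gives 8300 nM. Compound 2 `S=C(N/N=C/c1cccs1)Nc1ccccc1` gives 74700 nM.

Compound 4 `CCc1ccc(NC(=S)N/N=C/c2cccs2)cc1` has ethyl in place of methoxy on an aromatic carbon, para to a large group: ethyl in place of methoxy on an aromatic carbon. Among the compounds with values here, three measured steps bear on this place. a 9.0-fold higher number from compound 1 to compound 2 (0.95 log units; beyond the scatter) and an at least 12-fold higher number from compound 1 to compound 3 (1.08 log units; beyond the scatter) both lie beyond the scatter, while the floor of an at least 1.3-fold higher number from compound 2 to compound 3 (0.12 log units; that floor lies within the scatter) lies within it. Within the data shown here, no measured step brings in ethyl, so the direction is tentative. A modest move toward a lower number is expected, smaller than an at least 12-fold higher number from compound 1 to compound 3 (1.08 log units; beyond the scatter), leaving compound 4 nearer compound 2 at 74700 nM than compound 1. The estimated step is an at least 2.8-fold lower number from compound 3 to compound 4 (0.45 log units; beyond the scatter). Compound 4 is expected at 35000 nM, with an estimated range of 10000 nM to 100000 nM.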

Compound 4, concentration for 50% growth inhibition: > 100000 nM
Compound 4: a limit, no number (the forecaster's own chance of this, stated with the estimate: 25%); at least 2.8-fold (0.45 log units) between middle value and limit.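

In this assay compound 4 gives > 100000 nM, a limit and not a number, and ethyl becomes the second group at this position to end there: the limit of > 100000 nM in this assay, at which 2 of the 4 values shown sit.

Chloro remains clearly separated, with an at least 12-fold higher number from compound 1 to compound 4 (1.08 log units; beyond the scatter), while the comparison with hydrogen gives an at least 1.3-fold higher number from compound 2 to compound 4 (0.12 log units; that floor lies within the scatter), so ethyl cannot be told apart from hydrogen on these data. The step between the two limits cannot be read, which leaves ethyl and methoxy unordered.

The compounds shown leave open whether the lower number of compound 1 belongs to chloro alone or extends to other halogens, such as fluoro or bromo, at the same place. They also leave open how an amine or a longer chain at this place would read out.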